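The source may hold more compounds than are shown below. What is called first, only, known or untested is meant among the compounds shown, and "the series" means these compounds.

Values so far in an ADME assay on a cell-free system (plasma, Homo sapiens) for protein binding; a lower number here means a smaller unbound share, a higher number a larger unbound share of the compound
Compound 1 `Cc1cc(C)c2cc(C(=O)NC3CN(c4cc(Cl)ncc4Cl)C3)ccc2n1` gives 0.002
Compound 2 `Cc1cc(C)c2cc(C(=O)NC3CN(c4ccnc(F)c4F)C3)ccc2n1` gives 0.009

Compound 2 holds the higher of the two numbers. Compound 3 `COc1cc(N2CC(NC(=O)c3ccc4nc(C)cc(C)c4c3)C2)c(Cl)cn1` is unmeasured, and the change from compound 2 is 5-chloro-2-methoxypyridin-4-yl in place of 2,3-difluoropyridin-4-yl on an amine nitrogen in a ring. Within the data shown here, the one measured step at this place is modest, a 4.5-fold higher number from compound 1 to compound 2 (0.65 log units; beyond the scatter) (a change of group on the same nitrogen). The entering group carries chlorine, as the group of compound 1 does, so a partial return toward compound 1 is expected. The expected step in this assay is a 3.0-fold lower number from compound 2 to compound 3 (0.48 log units; beyond the scatter) (a lower number, of similar size to the measured step). For compound 3 the estimate is 0.003 (range 0.001 to 0.007).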

Compound 3, unbound fraction: 0.002
Estimate against measurement, compound 3: 1.5-fold (0.18 log units) above; low and high end bracket the measured number.
By their numbers in this assay, from the lowest: compounds 1 and 3 (each within the scatter of the next); then compound 2.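

In this assay, the exchange of 2,3-difluoropyridin-4-yl for 5-chloro-2-methoxypyridin-4-yl on the amine nitrogen reverses the earlier gain (a 4.5-fold lower number from compound 2 to compound 3 (0.65 log units; beyond the scatter)). Methoxy in place of chloro on an aromatic carbon leaves the number unmoved (no change at the digits printed from compound 1 to compound 3 (within the scatter)), so among these three compounds, only compound 2 stands apart. No measurement at hand offers a reason for either step.

Still open, on these data alone, is whether the higher number of compound 2 depends on the absence of chlorine from the pyridine. Also open, as far as these compounds go, is whether an amine in place of methoxy would move the number from that of compound 3.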